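The source may hold more compounds than are shown below. What is called first, only, known or untested is meant among the compounds shown, and "the series" means these compounds.

Compound 3 `CN1CCC[C@@H]1Cn1nc(Cc2ccc(F)cc2)c2ccccc2c1=O` stands lowest among the two numbers given in an assay for binding affinity to Alpha-1A adrenergic receptor (Homo sapiens); a higher number here means a weaker inhibitor, a lower number a stronger inhibitor: in this assay compound 3 gives 63.1 nM. Its nearest neighbour is compound 1 `CN1CCC[C@@H]1Cn1nc(Cc2ccc(O)cc2)c2ccccc2c1=O`, which gives 251 nM, so the exchange of hydroxy for fluoro is a 4.0-fold lower number from compound 1 to compound 3 (0.60 log units; beyond the scatter). Compound 2 `CN1CCC[C@@H]1Cn1nc(Cc2ccc(C(C)(C)C)cc2)c2ccccc2c1=O` returns no number but a limit of the assay, > 1990 nM. This is the limit of > 1990 nM in this assay, at which 1 of the 3 values shown sits. The exchange of hydroxy for tert-butyl is therefore an at least 7.9-fold higher number from compound 1 to compound 2 (0.89 log units; beyond the scatter), and the exchange of tert-butyl for fluoro is an at least 31-fold lower number from compound 2 to compound 3 (1.49 log units; beyond the scatter).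

Compound 4 `COC(=O)c1ccc(Cc2nn(C[C@H]3CCCN3C)c(=O)c3ccccc23)cc1` differs from compound 3 in one place: methoxycarbonyl in place of fluoro on an aromatic carbon. Among the measured compounds shown here, no measured step involves a methoxycarbonyl, so the three steps bear on it only indirectly. They show that the small fluoro gives the lowest number, the hydroxy a modestly higher one, and the bulky tert-butyl only a limit. The entering methoxycarbonyl is larger than the fluoro it replaces, so a higher number is expected for compound 4, of a size between the modest and the large steps seen, namely a 6.3-fold higher number from compound 3 to compound 4 (0.80 log units; beyond the scatter). Compound 4 is thus estimated at 400 nM in this assay, with a range from 100 nM to 2500 nM.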

Compound 4, inhibition constant: > 1990 nM
Compound 4 ended at the assay's limit (the forecaster's own chance of this, stated with the estimate: 20%); at least 4.9-fold (0.69 log units) between middle value and limit.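

Among the compounds shown here, compound 4 gives only a limit of the assay, so at this position, on an aromatic carbon para to a large group, tert-butyl in compound 2 is no longer the only group to end there: the limit of > 1990 nM in this assay, at which 2 of the 4 values shown sit. In this assay, methoxycarbonyl in place of fluoro gives an at least 31-fold higher number from compound 3 to compound 4 (1.49 log units; beyond the scatter), and methoxycarbonyl in place of hydroxy gives an at least 7.9-fold higher number from compound 1 to compound 4 (0.89 log units; beyond the scatter). The two hydrogen-bond acceptors that methoxycarbonyl brings therefore do not keep the number near those of compound 1 and compound 3, while the step between compound 2 and compound 4 cannot be read, as both values are limits.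

The limits leave open how far compound 2 and compound 4 actually lie beyond compound 1 and compound 3, and whether either of them differs from the other at all. The compounds shown also leave open how this position would respond to a chlorine atom, a methoxy group, an amine or a carboxylic acid, and so whether any group other than fluoro or hydroxy gives a number clear of the limit.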